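A Bromine-to-Chlorine Swap at the Edge of Detection

The compounds below may be only part of what the source reports. "The series", "measured", "known", "first", "only" and "open" are said of these compounds alone.

Compound 1, `O=C(CSc1nnc(NC(=O)c2c(Cl)cccc2Cl)s1)Nc1ccc(Br)cn1`, gives 18600 nM in a functional assay on A875 cells (Homo sapiens) for antiproliferative activity, read by MTT assay, with a stated time of 48 h; on this read-out higher numbers stand for weaker inhibition and lower numbers for stronger inhibition.
Compound 2, `COc1ccccc1C(=O)Nc1nnc(SCC(=O)Nc2ccc(Br)cn2)s1`, gives > 80000 nM in this assay.

Compound 2 stands at the upper end of what has been recorded. In this assay the figure for compound 2 is a limit of the assay and not a number, the one described as the limit of > 80000 nM in this assay, at which 1 of the 2 values shown sits. Going by the values given here, the only measured step, an at least 4.3-fold higher number from compound 1 to compound 2 (0.63 log units; beyond the scatter), concerns the group on the carbonyl carbon and says nothing about the halogen on the other end of the molecule.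

Compound 3, `COc1ccccc1C(=O)Nc1nnc(SCC(=O)Nc2ccc(Cl)cn2)s1`, differs from compound 2 in one place: chloro in place of bromo on an aromatic carbon. Among the compounds with values here, no measured step bears on this change, so there is nothing among the measured compounds to suggest a shift in either direction. On that basis compound 3 is expected to sit where compound 2 does, with a step that the limit leaves unreadable from compound 2 to compound 3 that stays within the scatter. The estimate for compound 3 in this assay is 90000 nM, with a range from 40000 nM to 200000 nM, and a real chance that only a limit is reported again.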

Compound 3, half-maximal inhibitory concentration: > 80000 nM
Compound 3: only a limit was reported (the forecaster's own chance of this, stated with the estimate: 70%); the middle value does not contradict the limit.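

Compound 3 gives only a limit of the assay, > 80000 nM. With compound 2 and compound 3 both resting on limits, no step between them can be read: the limit of > 80000 nM in this assay, at which 2 of the 3 values shown sit.

The compounds shown leave open whether 5-chloropyridin-2-yl and 5-bromopyridin-2-yl differ at all in this assay, with either carbonyl group.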